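Swapping One Halogen on the More Potent Compound

A few compounds are considered here, and "the series" means these few. Any claim that something is new, unique, unknown or untested is made for them only; others in the source may bear on it.

In a functional assay on T29Kt1 cells (Homo sapiens) for cytotoxicity, read by sulforhodamine B assay, with a stated time of 3 days (a lower number here means a stronger inhibitor, a higher number a weaker inhibitor), compound 1 (`O=CC1C(=O)N(Cc2ccc(Cl)cc2)c2cc(Cl)ccc21`) reads 18200 nM while compound 2 (`OCc1cn(Cc2ccc(Cl)cc2)c2ccccc12`) reads 79 nM and so holds the lower of the two numbers, with a gap well beyond the scatter of repeat measurements. Compound 2 is therefore the stronger inhibitor of this pair.

Compound 3 (`OCc1cn(Cc2ccc(Br)cc2)c2ccccc12`) differs from compound 2 in one place (bromo in place of chloro on an aromatic carbon): bromo in place of chloro on an aromatic carbon, para to a large group. For the measured compounds named here, no measured pair shows what this exchange does, and compounds 1 and 2 differ in more than one place, so their gap offers no guide to it. The expectation in this assay is therefore no step beyond the scatter, in either direction, with compound 3 staying close to compound 2 at 79 nM in this swap of one halogen for another. Only a small change is expected, an estimated 1.1-fold higher number from compound 2 to compound 3 (0.03 log units; within the scatter) that stays within the scatter. For compound 3 the estimate is 85 nM with an expected range of 30 nM to 240 nM for a repeat measurement.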

Compound 3, half-maximal inhibitory concentration: 390 nM
Compound 3: middle estimate off by 4.6-fold (0.66 log units), on the low side, and the stated range ends below it.
By their numbers in this assay, from the lowest: compound 2; then compound 3; then compound 1.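

In this assay, placing bromo instead of chloro on the aromatic carbon para to a large group gives a 4.9-fold higher number from compound 2 to compound 3 (0.69 log units; beyond the scatter) and so weakens the compound by a modest but real margin. The earlier compounds shown here could not show this, since compounds 1 and 2 differ in more than one place, whereas compounds 2 and 3 isolate a single exchange at this position. The group that leaves and the group that enters each count as one heavy atom, with no ring, no hydrogen-bond donors or acceptors and no net charge, yet the number still moves beyond the scatter, so this position does distinguish between these two halogens, and nothing available here explains the difference.

Among the compounds shown, only chloro and bromo appear at this position, which leaves open what a fluoro, a methoxy or an amine group would give there. Also open, from the compounds shown here alone, is whether the same exchange of chloro for bromo would give a step of similar size on a different core, such as the core of compound 1.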